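Swapping chloro for ethyl on the benzyl group

The source may report more compounds than this note shows. Statements on the series, on what has been measured and on what is new or still open speak of the compounds shown alone.

Compound 3 `CN(Cc1ccccc1)C(=O)c1cc2c(Cc3ccc(Cl)cc3)n[nH]c2cc1O` has no single number to stand on: in a functional assay on A2780 cells (Homo sapiens) for antiproliferative activity, read by resazurin assay, with a stated time of 72 h (on this read-out lower numbers stand for stronger inhibition and higher numbers for weaker inhibition), its entry reads "not determined" (no result reported) and nothing more. Compound 1 `CN(Cc1ccccc1)C(=O)c1cc2c(Cc3ccccc3Cl)n[nH]c2cc1O` is in the same position, with the entry "not determined" (no result reported) for this measurement. Going by the values given here, the only real number comes from compound 2 `Cc1cccc(Cc2n[nH]c3cc(O)c(C(=O)N(C)Cc4ccccc4)cc23)c1` at 490 nM in this family. The step ethyl in place of chloro on an aromatic carbon puts ethyl in place of chloro on an aromatic carbon, turning 4-chlorobenzyl into 4-ethylbenzyl. Among the compounds with values here, no measured step shows what such a swap does, so the expected change from the one measured relative is none beyond the scatter, resting on compound 2 at 490 nM as the sole anchor. Compound 4 `CCc1ccc(Cc2n[nH]c3cc(O)c(C(=O)N(C)Cc4ccccc4)cc23)cc1` is expected near 500 nM with an estimated range of 150 nM to 1600 nM in this read-out.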

Compound 4, half-maximal inhibitory concentration: > 10000 nM
Compound 4 was reported as a limit; the forecaster's own chance of this, stated with the estimate: 10%; middle value at least 20-fold (1.30 log units) from the limit.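

In this assay, the benzyl group on the shared core proves sensitive to a small change: 4-ethylphenyl in place of 3-methylphenyl gives an at least 20-fold higher number from compound 2 to compound 4 (1.30 log units; beyond the scatter). The reading for compound 4 is a limit, not a number: the limit of > 10000 nM in this assay, at which 1 of the 4 values shown sits.

Going by these compounds alone, the step from compound 3 to compound 4 cannot be read, so the swap of chloro for ethyl has no size, and the one readable step does not separate the longer chain from its new place on the ring. From the compounds shown here alone, how an amine or a carboxylic acid on this ring would fare also stays open.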